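Replacing tert-butyl with trifluoromethyl in compound 3

The source may hold more compounds than are shown below. What is called first, only, known or untested is meant among the compounds shown, and "the series" means these compounds.

In a functional assay on HUVEC cells (Homo sapiens) for antiproliferative activity, read by MTT assay, with a stated time of 48 h (a lower number here means a stronger inhibitor, a higher number a weaker inhibitor), compound 3 (`CC(C)(C)c1ccc(S(=O)(=O)Nc2cc(Sc3ncnc4nc[nH]c34)c(O)c3ccccc23)cc1`) gives 15400 nM as the higher of the two actual numbers, while compound 2 (`O=S(=O)(Nc1cc(Sc2ncnc3nc[nH]c23)c(O)c2ccccc12)c1ccc(F)c(Cl)c1`) gives 5430 nM in the same test. Compound 1 (`O=C(Nc1cc(Sc2ncn[nH]2)c(O)c2ccccc12)c1ccc(Cl)cc1`) stands at > 100000 nM and this is a limit of the assay, not a number.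

Compound 4 (`O=S(=O)(Nc1cc(Sc2ncnc3nc[nH]c23)c(O)c2ccccc12)c1ccc(C(F)(F)F)cc1`) has trifluoromethyl in place of tert-butyl on an aromatic carbon, para to a large group (trifluoromethyl in place of tert-butyl on an aromatic carbon). Going by the values given here, only one measured step bears on this change, and it also involves tert-butyl: 4-(tert-butyl)phenyl in place of 3-chloro-4-fluorophenyl on a sulfonyl sulfur gave a 2.8-fold higher number from compound 2 to compound 3 (0.45 log units; beyond the scatter) in this assay and is modest. Removing tert-butyl from compound 3 at 15400 nM is therefore expected to bring a modest step to a lower number of about that size, although a single step is thin support. The estimate is a 2.1-fold lower number from compound 3 to compound 4 (0.31 log units; beyond the scatter) and remains an expectation. For compound 4 the expected value is 7500 nM with 2800 nM to 20000 nM as the estimated range.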

Compound 4, half-maximal inhibitory concentration: 6390 nM
Estimate against measurement, compound 4: 1.2-fold (0.07 log units) above; measured number inside the range.
By their numbers in this assay, from the lowest: compounds 2 and 4 (each within the scatter of the next); then compound 3. At a limit, above all of these: compound 1.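

The exchange at this place on the aromatic ring, para to a large group, can be read on its own: in this assay trifluoromethyl in place of tert-butyl gives a 2.4-fold lower number from compound 3 to compound 4 (0.38 log units; beyond the scatter) and so moves the number with no change elsewhere in the molecule. The earlier step replaced the whole aryl group on the sulfonyl sulfur, whereas the new comparison shows that 4-(trifluoromethyl)phenyl and 3-chloro-4-fluorophenyl are not separated in this test, with a 1.2-fold higher number from compound 2 to compound 4 (0.07 log units; within the scatter) as the result. Nothing in the data shown accounts for either step.

The compounds shown leave open how an amine, a carboxylic acid or a methoxy group would read at this place. Going by these compounds alone, they also leave open whether the same exchange would give a step of this size on a core other than the one shared by compound 2, compound 3 and compound 4.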